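The source may report more compounds than this note shows. Statements on the series, on what has been measured and on what is new or still open speak of the compounds shown alone.

Measured so far in a functional assay on Caco-2 cells (Homo sapiens) for cytotoxicity, with a stated time of 48 h; a higher number here means a weaker inhibitor, a lower number a stronger inhibitor: compound 1, `O=[N+]([O-])c1ccc(CN2CCC(n3cc(CC(OCc4cc(-c5ccccc5)no4)c4ccc(Br)cc4)nn3)CC2)cc1`, gives 7000 nM; compound 2, `COc1ccc(-c2cc(COC(Cc3cn(C4CCN(Cc5ccc([N+](=O)[O-])cc5)CC4)nn3)c3ccc(Br)cc3)on2)cc1`, gives 3000 nM.

For the measured compounds named here, compound 2 stands at the lower of these two numbers, and the single measured step, a 2.3-fold lower number from compound 1 to compound 2 (0.37 log units; beyond the scatter), lies beyond the scatter. Compound 3, `O=[N+]([O-])c1ccc(CN2CCC(n3cc(CC(OCc4cc(-c5ccccc5F)no4)c4ccc(Br)cc4)nn3)CC2)cc1`, carries 2-fluorophenyl in place of 4-methoxyphenyl on an aromatic carbon. Going by the values given here, only that one step bears on this change, and only in part: it shows what the methoxy group on the phenyl ring added, a 2.3-fold lower number from compound 1 to compound 2 (0.37 log units; beyond the scatter), so removing it again should give back roughly that much. Nothing measured tells what the fluorine on the entering ring contributes, which widens the uncertainty. The step from compound 2 to compound 3 is therefore expected to be a modest rise, a 2.0-fold higher number from compound 2 to compound 3 (0.30 log units; within the scatter). For compound 3 the estimated value in this assay is 6000 nM, with a range from 2500 nM to 15000 nM.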

Compound 3, half-maximal inhibitory concentration: 4000 nM
For compound 3 the middle estimate is 1.5-fold (0.18 log units) above the measured one, within the range that was stated.
By their numbers in this assay, from the lowest: compounds 2, 3 and 1 (each within the scatter of the next, the first and the last beyond it).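

In this assay, the step with 2-fluorophenyl in place of 4-methoxyphenyl on this aromatic carbon is a 1.3-fold higher number from compound 2 to compound 3 (0.12 log units; within the scatter) and does not separate the two groups. The fluoro in place of hydrogen gives a 1.8-fold lower number from compound 1 to compound 3 (0.24 log units; within the scatter) and so adds a second substituent on this phenyl ring whose step stays inside the scatter, unlike the methoxy step, a 2.3-fold lower number from compound 1 to compound 2 (0.37 log units; beyond the scatter), which lies beyond it. Nothing available explains these numbers.

The compounds shown leave open whether the difference between the methoxy and fluoro steps belongs to the group or to its place on the ring, which 2-methoxyphenyl or 4-fluorophenyl would address. They also leave open how an amine or a carboxylic acid on this phenyl ring would read in this assay.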